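Swapping the Phenoxy Group on the Shared Core

The compounds below may be only part of what the source reports. "The series", "measured", "known", "first", "only" and "open" are said of these compounds alone.

Of the compounds shown here, three have so far been measured in an ADME assay on microsomes from liver (Homo sapiens) for metabolic stability, read by LC-MS, using NADPH, with stated times of 5 min and 30 min, tested at 1 uM; a higher number here means faster removal of the compound, a lower number slower removal. Compound 1 `CN(c1ccn(C)n1)c1cnc(NCc2c(F)ccc3c2CCO3)c2cn[nH]c(=O)c12` gives 62 mL.min-1.g-1, compound 2 `CN(C)C(=O)c1cc(-c2cnc(NCc3c(F)ccc4c3CCO4)c3cn[nH]c(=O)c23)n(C)n1` gives 21 mL.min-1.g-1, and compound 3 `Fc1ccc2c(c1CNc1ncc(Oc3ccccc3)c3nncn13)CCO2` gives 18 mL.min-1.g-1. Compound 3 stands lowest of the three numbers: compound 2 is its nearest neighbour, within the scatter, while compound 1 lies furthest, beyond the scatter. Going by the values given here, the only step between compounds that differ in one place is a 3.0-fold lower number from compound 1 to compound 2 (0.47 log units; beyond the scatter), an exchange of one group for another on an aromatic carbon that moved the read-out modestly.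

The next compound is compound 4 `O=C1CC2(CC2)CN1c1cnc(NCc2c(F)ccc3c2CCO3)n2cnnc12`. It differs from compound 3 as follows: a group of 8 heavy atoms (6 carbon, 1 nitrogen, 1 oxygen; one three-membered non-aromatic ring of carbon only, one five-membered non-aromatic ring with 1 hetero atom) in place of a group of 7 heavy atoms (6 carbon, 1 oxygen; one six-membered aromatic ring of carbon only), on an aromatic carbon. Among the compounds with values here, no measured step exchanges a phenoxy, and no measured step places a new group at this position of the core, so the step from compound 1 to compound 2 shows only that such an exchange can shift this assay modestly; it does not say in which direction this one will go. Compound 3 already sits at the low end of the measured range, and a group of similar size enters.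

Compound 4 is therefore expected to give 15 mL.min-1.g-1, with a range from 6 mL.min-1.g-1 to 36 mL.min-1.g-1. This estimate means an expected step of a 1.2-fold lower number from compound 3 to compound 4 (0.08 log units; within the scatter), not beyond the scatter.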

Compound 4, intrinsic clearance in microsomes: < 3 mL.min-1.g-1
Compound 4 was reported as a limit (the forecaster's own chance of this, stated with the estimate: 10%); middle value at least 5.0-fold (0.69 log units) away from the limit.
By their numbers in this assay, from the lowest: compounds 3 and 2 (each within the scatter of the next); then compound 1. At a limit, below all of these: compound 4.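

This change shows that the position is not neutral in this assay, even starting from compound 3 at the low end of the measured range: exchanging the phenoxy on the aromatic carbon for the group with a three-membered ring of carbon only and a five-membered non-aromatic ring gives an at least 6.0-fold lower number from compound 3 to compound 4 (0.77 log units; beyond the scatter). The figure for compound 4 is a limit of the assay and not a number: the limit of < 3 mL.min-1.g-1 in this assay, at which 1 of the 4 values shown sits. The step therefore has a bound but no fixed size, and since the leaving and entering groups have the same counts of hydrogen-bond donors and acceptors and neither carries a net charge, those counts do not distinguish the two groups, whereas the aromatic ring that leaves and the non-aromatic rings that enter do.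

The compounds shown leave open which part of the entering group goes with the step: the three-membered ring, the five-membered ring or the carbonyl. They also leave open how an open-chain amine or a morpholine at this position would read in this assay, and whether the same exchange would give a comparable step on the core of compound 1.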